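Benzyl for 4-fluorophenyl on the nitrogen of compound 2

The source may hold more compounds than are shown below. What is called first, only, known or untested is meant among the compounds shown, and "the series" means these compounds.

Of the compounds shown here, two on the shared core have been read so far in an ADME assay on A549 cells (Homo sapiens) for cytotoxicity, read by MTT assay, with a stated time of 4 days (on this read-out higher numbers stand for weaker inhibition and lower numbers for stronger inhibition), on this series. Compound 1 (`COc1ccc(Nc2ccc(C[C@H]3C(=O)OC[C@@H]3Cc3ccc(OC)c(OC)c3)cc2OC)cc1`) gives > 50000 nM as a limit of the assay, not a number. Compound 2 (`COc1cc(C[C@H]2C(=O)OC[C@@H]2Cc2ccc(OC)c(OC)c2)ccc1Nc1ccc(F)cc1`) gives > 50000 nM as a limit too. Compound 2 thus stands at the limit of > 50000 nM in this assay, at which 2 of the 2 values shown sit, and has no number of its own. Among the measured compounds shown here, the only measured step is a step that the two limits leave unreadable from compound 1 to compound 2 and concerns fluoro in place of methoxy on an aromatic carbon. It offers no size to carry forward.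

The change to compound 3 (`COc1cc(C[C@H]2C(=O)OC[C@@H]2Cc2ccc(OC)c(OC)c2)ccc1NCc1ccccc1`) is benzyl in place of 4-fluorophenyl on a nitrogen on an aromatic ring, counted as benzyl in place of 4-fluorophenyl on a nitrogen on an aromatic ring for the record. For the measured compounds named here, no measured step covers this change, so the expectation rests only on compound 2 at > 50000 nM as a limit. Another limit reading is the likeliest result. The expected step is an at least 1.1-fold lower number from compound 2 to compound 3 (0.04 log units; that floor lies within the scatter) with no firm direction expected in this assay from so little. Compound 3 is expected at 45000 nM with an estimated range from 15000 nM to 90000 nM in this read-out.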

Compound 3, half-maximal inhibitory concentration: > 50000 nM
Compound 3 gave a limit, no number; the forecaster's own chance of this, stated with the estimate: 65%; middle value at least 1.1-fold (0.04 log units) away from the limit.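

Compound 3, like compound 1 and compound 2, gives only a limit and not a number, so no step among these compounds can be read: the limit of > 50000 nM in this assay, at which 3 of the 3 values shown sit.

Still open, from the compounds shown here alone, is whether any group on the nitrogen of the shared core gives a readable number in this assay.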